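From a 3-nitrophenyl to a 4-methoxyphenyl group

The source may report more compounds than this note shows. Statements on the series, on what has been measured and on what is new or still open speak of the compounds shown alone.

Measured so far:
Compound 1, `Nc1ccccc1NC(=O)c1ccc(NCC(=O)Nc2cccc([N+](=O)[O-])c2)cc1`: 40.4%
Compound 2, `Nc1ccccc1NC(=O)CCCNCC(=O)Nc1cc(Cl)ccc1Cl`: 50.9%

Both compounds were tested in a functional assay on the whole organism (Ehrlich cells, Mus musculus) for antiproliferative activity, with a stated time of 24 h, at a dose of 0.2 mmol/kg by the intraperitoneal route; a lower number here means less inhibition, a higher number more inhibition at the dose given (going by the name of the read-out). Compound 1 gives 40.4% and stands at the lower end of the two numbers shown; the only neighbour, compound 2, gives 50.9%, which is higher by a margin beyond the usual scatter. Compound 1 and compound 2 differ in more than one place, so their two values can only be read side by side, not as a single step with one cause.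

The next compound, compound 3, `COc1ccc(NC(=O)CNc2ccc(C(=O)Nc3ccccc3N)cc2)cc1`, is built from compound 1 by one change: 4-methoxyphenyl in place of 3-nitrophenyl on an amide-type nitrogen. Going by the values given here, no measured pair shows what this kind of exchange does in this assay, so nothing is known here about its size or direction. Without such a guide, the expectation is a step no larger than the scatter, in either direction. The step of a number 1.6 percentage points higher from compound 1 to compound 3 (within the scatter) is therefore expected to be small, none beyond the scatter. Compound 3 is estimated to give 42%, with a range from 25% to 60%.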

Compound 3, a percentage reported as inhibition, in the whole organism at one dose (the size of the read-out at that dose, not a potency): 62.3%
Beside the measured number, compound 3's estimate is 20.3 percentage points below it; measured number outside the range, above it.
By their numbers in this assay, from the lowest: compound 1; then compound 2; then compound 3.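

In this assay, replacing 3-nitrophenyl with 4-methoxyphenyl on the amide-type nitrogen gives a step of a number 21.9 percentage points higher from compound 1 to compound 3 (beyond the scatter) and the rest of the molecule stays the same. Going by these compounds alone, this is the first comparison that can be tied to a single place, as the two earlier compounds differ in more than one place and could only be read side by side. It shows that the group on this nitrogen can shift the inhibition seen at this dose by more than the usual scatter, but nothing measured here explains why the number rises.

The step changes two things at once, the kind of substituent on the ring and where it sits, so a 3-methoxyphenyl group would be needed to tell these two apart. A plain phenyl group on the same nitrogen would show whether the 3-nitrophenyl group lowers the inhibition, the 4-methoxyphenyl group raises it, or both contribute, and since this is a single reading at one dose, it says nothing about potency.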